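Swapping the nitrophenyl arm for a methoxyphenyl one

The source may hold more compounds than are shown below. What is called first, only, known or untested is meant among the compounds shown, and "the series" means these compounds.

Of the compounds shown here, three sharing one core have been measured in an assay on isolated protein for binding affinity to Equilibrative nucleoside transporter 1 (Homo sapiens); on this read-out lower numbers stand for stronger inhibition and higher numbers for weaker inhibition. Compound 1 `OC[C@H]1O[C@@H](n2cnc3c(NCc4ccco4)ncnc32)[C@H](O)[C@@H]1O` gives 36300 nM. Compound 2 `O=[N+]([O-])c1ccc(CNc2ncnc3c2ncn3[C@@H]2O[C@H](CO)[C@@H](O)[C@H]2O)c(Cl)c1` gives 347 nM, and compound 3 `Cc1cc(CNc2ncnc3c2ncn3[C@@H]2O[C@H](CO)[C@@H](O)[C@H]2O)ccc1[N+](=O)[O-]` gives 87.1 nM, the lowest of the three numbers. The steps are a 100-fold lower number from compound 1 to compound 2 (2.02 log units; beyond the scatter) and a 420-fold lower number from compound 1 to compound 3 (2.62 log units; beyond the scatter), both large, while a 4.0-fold lower number from compound 2 to compound 3 (0.60 log units; beyond the scatter) is modest.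

Compound 4 `COc1cccc(CNc2ncnc3c2ncn3[C@@H]2O[C@H](CO)[C@@H](O)[C@H]2O)c1` has not been measured. It differs from compound 3 by 3-methoxyphenyl in place of 3-methyl-4-nitrophenyl on a saturated chain carbon bound to a nitrogen on an aromatic ring. For the measured compounds named here, no measured step removes the nitrophenyl pattern altogether; the two large steps only show that a nitrophenyl in place of furan-2-yl is strongly favoured, and the modest step that the substituent beside the nitrophenyl matters less. Compound 4 keeps a six-membered carbon ring but not the nitrophenyl pattern, so a sizeable move toward higher numbers, a 29-fold higher number from compound 3 to compound 4 (1.46 log units; beyond the scatter), is expected in this assay, though its size is uncertain. For compound 4 the estimate in this assay is 2500 nM, with a range from 300 nM to 20000 nM.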

Compound 4, half-maximal inhibitory concentration: 115000 nM
For compound 4 the middle estimate is 46-fold (1.66 log units) below the measured one, outside the stated range (above it).
By their numbers in this assay, from the lowest: compound 3; then compound 2; then compound 1; then compound 4.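

Within this assay, the arm on the saturated chain carbon bound to a nitrogen on an aromatic ring proves decisive: the change to 3-methoxyphenyl gives a 1300-fold higher number from compound 3 to compound 4 (3.12 log units; beyond the scatter) and a 330-fold higher number from compound 2 to compound 4 (2.52 log units; beyond the scatter), both large, so a six-membered carbon ring alone does not preserve the low numbers of the nitrophenyl compounds. Nor does that ring by itself improve on furan-2-yl, as the comparison gives a 3.2-fold higher number from compound 1 to compound 4 (0.50 log units; beyond the scatter), a modest step in the opposite direction. No measurement shown here explains this loss.

Compound 4 loses the nitro and methyl groups and gains methoxy in one change, leaving open which of these accounts for the shift. Also open, as far as these compounds go, is how a phenyl ring carrying an amine or a carboxylic acid would read in this assay.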